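This account rests on a few compounds, and the source may have more. Where it says the series, first, only, none or still open, it means among the compounds named here.

Measured so far in a functional assay on MCF cells (Homo sapiens) for antiproliferative activity, with a stated time of 72 h; a higher number here means a weaker inhibitor, a lower number a stronger inhibitor:
Compound 1, `OC[C@H]1O[C@@H](n2cnc3c(NCc4ccccc4F)ncnc32)[C@H](O)[C@@H]1O`, gives > 166000 nM, a limit of the assay rather than a number.
Compound 2, `OC[C@H]1O[C@@H](n2cnc3c(NCc4cccc(F)c4)ncnc32)[C@H](O)[C@@H]1O`, gives 15300 nM.
Compound 3, `COc1ccc(CNc2ncnc3c2ncn3[C@@H]2O[C@H](CO)[C@@H](O)[C@H]2O)c(OC)c1`, gives > 166000 nM, again a limit of the assay.

Compound 1 therefore stands at the assay limit (the limit of > 166000 nM in this assay, at which 2 of the 3 values shown sit), where compound 3 also sits, while compound 2 alone returns a number. Compound 4, `OC[C@H]1O[C@@H](n2cnc3c(NCc4ccc(F)cc4F)ncnc32)[C@H](O)[C@@H]1O`, differs from compound 1 by fluoro in place of hydrogen on an aromatic carbon. Within the data shown here, no measured step touches this same position. The nearest evidence is an at least 10-fold lower number from compound 1 to compound 2 (1.03 log units; beyond the scatter), which moves the single fluoro rather than adding a second, and an at least 10-fold higher number from compound 2 to compound 3 (1.03 log units; beyond the scatter), where the 2,4-dimethoxyphenyl compound returns to the limit. Neither reads directly on a second fluoro added to the ring of compound 1, and since compound 1 is itself a limit, the step to compound 4 can only be guessed; a weak inhibitor is expected, with an estimated step of an at least 1.3-fold lower number from compound 1 to compound 4 (0.14 log units; that floor lies within the scatter). Compound 4 is estimated at 120000 nM, range 20000 nM to 400000 nM, with a fair chance that the assay again reports only a limit.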

Compound 4, half-maximal inhibitory concentration: > 166000 nM
Compound 4: no number, only a limit (the forecaster's own chance of this, stated with the estimate: 55%); at least 1.3-fold (0.14 log units) between middle value and limit.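

In this assay compound 4 gives > 166000 nM, which is a limit of the assay. Among these compounds, the added fluoro does not bring the 2,4-difluorobenzyl group into measurable range, and the one readable step is an at least 10-fold higher number from compound 2 to compound 4 (1.03 log units; beyond the scatter). The steps linking compound 4 with compound 1 and compound 3 cannot be read, and compound 2 remains the only compound with a number: the limit of > 166000 nM in this assay, at which 3 of the 4 values shown sit.

From the compounds shown here alone, how far compound 1 and compound 4 lie past the limit stays open. Also open, going by these compounds, is whether an amine or a carboxylic acid in place of the fluoro of compound 2 would keep a measurable value.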